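The source may report more compounds than this note shows. Statements on the series, on what has been measured and on what is new or still open speak of the compounds shown alone.

Measured so far in a functional assay on MGC-803 cells (Homo sapiens) for antiproliferative activity, read by CCK-8 assay, with a stated time of 72 h, tested at 8 uM; a higher number here means a stronger effect of the compound at the concentration tested, a lower number a weaker effect:
- compound 1, `Nc1ccccc1NC(=O)c1ccc(CSC(=S)N2CCCc3ccccc32)cc1`: 87.5%
- compound 2, `Nc1ccccc1NC(=O)c1ccc(CSC(=S)N2CCN(c3ccccc3F)CC2)cc1`: 86.4%

Compound 1 stands at the top of the two numbers in this assay, but the number of compound 2 sits within the scatter of it, so the two cannot be separated on these data. Going by the values given here, no step between measured compounds is available; the two simply show that two unlike groups on the thiocarbonyl carbon give the same level of inhibition.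

Compound 3, `CN(Cc1ccncc1)C(=S)SCc1ccc(C(=O)Nc2ccccc2N)cc1`, has not been measured in this assay. Relative to compound 1 the change is methyl((pyridin-4-yl)methyl)amino in place of 1,2,3,4-tetrahydroquinolin-1-yl on a thiocarbonyl carbon.

The step of a number 7.5 percentage points lower from compound 1 to compound 3 (within the scatter) is expected to be none beyond the scatter, or at most a small drop, since compound 2 already shows that another group at this position holds the value at 86.4%. For compound 3 the expected inhibition is 80%, within a range of 60% to 92%.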

Compound 3, a percentage reported as inhibition, at one concentration (the size of the read-out at that concentration, not a potency): 83.2%
Compound 3: the middle estimate sits 3.2 percentage points below what was measured; low and high end bracket the measured number.
By their numbers in this assay, from the lowest: compounds 3, 2 and 1 (each within the scatter of the next).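

Going by these compounds alone, with methyl((pyridin-4-yl)methyl)amino in place of 1,2,3,4-tetrahydroquinolin-1-yl on a thiocarbonyl carbon, this assay shows a number 4.3 percentage points lower from compound 1 to compound 3 (within the scatter) and provides the first readable step at this position. The level of inhibition therefore does not depend on the six-membered non-aromatic ring of the leaving group, and a six-membered aromatic ring with 1 hetero atom serves within the scatter in place of one of carbon only. No measured evidence bears on the reason for this.

These readings come from a single concentration, so any differences in potency among these groups remain open. As far as these compounds go, it also remains open whether a small open-chain group such as dimethylamino, or a piperidine carrying a carboxylic acid, would hold this level on the thiocarbonyl carbon.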